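Changing the group on the amino nitrogen

The compounds below may be only part of what the source reports. "The series", "measured", "known", "first", "only" and "open" are said of these compounds alone.

Compound 3 `FC(F)(F)c1ccc(CSc2nc(Nc3cccc(Br)c3)c3ccccc3n2)cc1` carries a 3-bromophenyl on a nitrogen on an aromatic ring. In a functional assay on MDA-MB-231 cells (Homo sapiens) for cytotoxicity, read by MTT assay, with a stated time of 72 h (on this read-out higher numbers stand for weaker inhibition and lower numbers for stronger inhibition), compound 3 gives 22100 nM, the highest of the two numbers obtained, with compound 1 `CCCCCCNc1nc(SCc2ccc(C(F)(F)F)cc2)nc2ccccc12` nearest at 20200 nM. Compound 2 `CCCCCCCCCCCCNc1nc(SCc2ccc(C(F)(F)F)cc2)nc2ccccc12` reaches only a limit of this assay, > 50000 nM. Two changes around that nitrogen have been measured. Lengthening the chain gave an at least 2.4-fold higher number from compound 1 to compound 2 (0.39 log units; beyond the scatter), whereas exchanging hexyl for 3-bromophenyl gave a 1.1-fold higher number from compound 1 to compound 3 (0.04 log units; within the scatter). Compound 4 `COc1ccc(Nc2nc(SCc3ccc(C(F)(F)F)cc3)nc3ccccc23)cc1OC` differs from compound 3 by 3,4-dimethoxyphenyl in place of 3-bromophenyl on a nitrogen on an aromatic ring. Among the compounds with values here, no measured step exchanges one aromatic group for another on that nitrogen, so the closest guide is the exchange of hexyl for 3-bromophenyl, which stayed within the scatter, while the only step beyond the scatter came from a longer saturated chain rather than from an aromatic group. A step of about a 1.0-fold lower number from compound 3 to compound 4 (0.00 log units; within the scatter) is therefore expected, meaning no shift beyond the scatter. Compound 4 is estimated at 22000 nM, between 8000 nM and 60000 nM.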

Compound 4, half-maximal inhibitory concentration: 18900 nM
Estimate against measurement, compound 4: 1.2-fold (0.07 log units) above; the measured number falls inside the stated range.
By their numbers in this assay, from the lowest: compounds 4, 1 and 3 (each within the scatter of the next). At a limit, above all of these: compound 2.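

Within the data shown here, on the nitrogen on an aromatic ring, this is the first exchange of one aromatic group for another, and in this assay it gives a 1.2-fold lower number from compound 3 to compound 4 (0.07 log units; within the scatter), while replacing the saturated chain gives a 1.1-fold lower number from compound 1 to compound 4 (0.03 log units; within the scatter). The 3,4-dimethoxyphenyl therefore brings more heavy atoms and hydrogen-bond acceptors that the 3-bromophenyl lacks, yet this read-out does not separate the two groups from each other or from hexyl. Nothing measured here gives a reason for this flat result.

Going by these compounds, it stays open whether any group on this nitrogen can move the number down beyond the scatter, as an unsubstituted phenyl, a benzyl or a butyl chain might show. On these data alone, it is also open whether a phenyl carrying an amine or a carboxylic acid would behave like the aromatic groups in compound 3 and compound 4.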